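One Stereocentre Drawn the Other Way

A few compounds are considered here, and "the series" means these few. Any claim that something is new, unique, unknown or untested is made for them only; others in the source may bear on it.

Of the compounds shown here, two have been measured so far in an ADME assay on Caco-2 cells (Homo sapiens) for permeability, read by LC-MS, with a stated time of 2 h, at pH 7.4, tested at 10 uM; a lower number here means that the compound crosses the layer more slowly, a higher number that the compound crosses the layer faster. In this test compound 1 `C[C@@H]1Cn2c(nnc2C(F)(F)F)CN1C(=O)c1cccc(C(F)(F)c2n[nH]c(=O)c3c2CCCC3)c1` gives 1.8 10^-6 cm/s and compound 2 `C[C@H]1Cn2c(nnc2C(F)(F)F)CN1C(=O)c1cccc(C(F)(F)c2n[nH]c(=O)c3ccccc23)c1` gives 6.7 10^-6 cm/s. Compound 2 therefore holds the higher of the two numbers, and the gap to compound 1 lies beyond the scatter. However, these two compounds do not differ at one place only, so no measured pair shows what a single change does.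

Compound 3 `C[C@@H]1Cn2c(nnc2C(F)(F)F)CN1C(=O)c1cccc(C(F)(F)c2n[nH]c(=O)c3ccccc23)c1` is the next to be considered. Its relation to compound 2 is simple: the two compounds have the same atoms and bonds and differ only in configuration as drawn: 1 of 1 stereo elements differ; a stereocentre at a saturated ring carbon is drawn S in compound 2 and R in compound 3. The two compounds have the same atoms and bonds, and a stereocentre at a saturated ring carbon is drawn S in compound 2 and R in compound 3. For the measured compounds named here, with no measured step to guide the size, no shift beyond the scatter is expected in this assay, and neither direction is favoured. The expected 1.1-fold lower number from compound 2 to compound 3 (0.05 log units; within the scatter) is therefore small. Compound 3 is estimated at 6 10^-6 cm/s, with a likely range from 2.8 10^-6 cm/s to 12 10^-6 cm/s in this test.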

Compound 3, apparent permeability: 7.9 10^-6 cm/s
The estimate for compound 3 lay 1.3-fold (0.12 log units) below the measured number; measured number inside the range.
By their numbers in this assay, from the lowest: compound 1; then compounds 2 and 3 (each within the scatter of the next).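

In this assay, for the compounds shown here, the stereocentre at the saturated ring carbon is the only thing that changes in one pair, and a 1.2-fold higher number from compound 2 to compound 3 (0.07 log units; within the scatter), so the S and R drawings cannot be told apart in this test. Going by these compounds alone, compound 3 also provides the first measured step at the other place: the group with one six-membered aromatic ring of carbon only, in place of the group with one six-membered non-aromatic ring of carbon only, on a saturated chain carbon bound to an aromatic carbon and two fluorine atoms, gives a 4.4-fold higher number from compound 1 to compound 3 (0.64 log units; beyond the scatter). Of the two places where the first two compounds differ, only this ring step therefore lies beyond the scatter, while the stereocentre comparison stands on a single clean pair: the fact that compounds 2 and 3 differ only in the configuration as drawn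

As far as these compounds go, whether the ring step holds with the other configuration drawn stays open, since it rests on one pair with one drawn configuration. The compounds shown also leave open what an amine or a methoxy group on the carbon-only ring would do to the number, and whether the stereocentre would still show no shift beyond the scatter if a nitrile took the place of the trifluoromethyl group.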